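The compounds below may be only part of what the source reports. "The series", "measured", "known", "first", "only" and "open" are said of these compounds alone.

In an ADME assay on HepG2 cells (Homo sapiens) for cytotoxicity, read by MTT assay, with a stated time of 48 h (a lower number here means that less compound is tolerated, a higher number that more compound is tolerated), compound 1 `CC(=O)N1C(=O)/C(=C(\Nc2ccc(CN3CCCCC3)cc2)c2ccccc2)c2cc([N+](=O)[O-])ccc21` reaches the limit of the assay and is recorded as > 6 uM. Compound 3 `CC(=O)N1C(=O)/C(=C(\Nc2ccc(CN3CCCCC3)cc2)c2ccccc2)c2cc(N)ccc21` in this assay gives 1.81 uM. Among the compounds with values here, the step of an at least 3.3-fold lower number from compound 1 to compound 3 (0.52 log units; beyond the scatter) is the only measured step here. Compound 2 `CC/C(Nc1ccc(CN2CCCCC2)cc1)=C1/C(=O)Nc2ccc(NS(=O)(=O)CC)cc21` in this assay is also recorded only as a limit, > 6 uM, and so stands where the limit of > 6 uM in this assay, at which 2 of the 3 values shown sit, places it, with no exact number. Compound 4 `CCS(=O)(=O)Nc1ccc2c(c1)/C(=C(\C)Nc1ccc(CN3CCCCC3)cc1)C(=O)N2` differs from compound 2 by hydrogen in place of methyl on a saturated chain carbon bound to a double-bonded chain carbon. Within the data shown here, no measured step touches this part of the molecule, so the change gives no basis for expecting a step beyond the scatter in either direction. Compound 4 is therefore expected to give about 8 uM, within 3 uM to 20 uM, an expected step that the limit leaves unreadable from compound 2 to compound 4.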

Compound 4, half-maximal toxic concentration: > 6 uM
Compound 4 ended at the assay's limit (the forecaster's own chance of this, stated with the estimate: 60%); the middle value is on the limit's open side.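

Compound 2 and compound 4 are both recorded only as limits in this assay, so the step between them cannot be read: the limit of > 6 uM in this assay, at which 3 of the 4 values shown sit. The compounds shown leave open whether replacing methyl with hydrogen here changes the tolerated concentration at all.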